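Compound 4: from aminocarbamoyl to carbamoyl

The source may report more compounds than this note shows. Statements on the series, on what has been measured and on what is new or still open speak of the compounds shown alone.

Among the compounds with values here, in a functional assay on HepG2 cells (Homo sapiens) for cytotoxicity, read by MTT assay, with a stated time of 48 h (a lower number here means a stronger inhibitor, a higher number a weaker inhibitor), compound 1 (`Cc1n[nH]c2c1C(c1ccc(N(C)C)cc1)C(C(=O)NN)=C(N)N2`) gives 66400 nM as its result, the highest number of the three measured so far. Compound 2 (`Cc1n[nH]c2c1C(c1ccc(N(C)C)cc1)C(C(=O)NNC(N)=S)=C(N)N2`) gives 6320 nM and compound 3 (`Cc1n[nH]c2c1C(c1ccc(N(C)C)cc1)C=C(N)N2`) gives 20600 nM in the same test. Compound 4 (`Cc1n[nH]c2c1C(c1ccc(N(C)C)cc1)C(C(N)=O)=C(N)N2`) has not been measured yet. It comes from compound 1 by one small edit (hydrogen in place of amino on an amide-type nitrogen): hydrogen in place of amino on an amide-type nitrogen, which turns aminocarbamoyl into carbamoyl.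

Within the data shown here, two measured steps bear on this edit. Building onto that amino group gave a large change (an 11-fold lower number from compound 1 to compound 2 (1.02 log units; beyond the scatter)), and removing aminocarbamoyl altogether gave a modest one (a 3.2-fold lower number from compound 1 to compound 3 (0.51 log units; beyond the scatter)). Both went to a lower number, yet neither is the same edit as this one, so only a modest step in that direction is expected (a 2.2-fold lower number from compound 1 to compound 4 (0.35 log units; beyond the scatter)) and a smaller one would be no surprise. The estimate for compound 4 is 30000 nM as a middle value, with an expected range from 12000 nM to 70000 nM for its result.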

Compound 4, half-maximal inhibitory concentration: 5280 nM
The estimate for compound 4 lay 5.7-fold (0.75 log units) above the measured number, and the stated range ends above it.
By their numbers in this assay, from the lowest: compounds 4 and 2 (each within the scatter of the next); then compound 3; then compound 1.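

Cutting aminocarbamoyl back to carbamoyl gave a 13-fold lower number from compound 1 to compound 4 (1.10 log units; beyond the scatter) in this assay, so the amino group on the amide-type nitrogen of compound 1 matters far more than the removal of the whole group had suggested. The carbamoyl that remains also counts, since adding it in place of hydrogen on the double-bonded ring carbon gave a 3.9-fold lower number from compound 3 to compound 4 (0.59 log units; beyond the scatter) in the same test. Removing that amino group and building onto it reach the same level, as the step between the two results shows (a 1.2-fold lower number from compound 2 to compound 4 (0.08 log units; within the scatter)), so two opposite edits of compound 1 end within the scatter of each other.

No measurement here explains why the amino group goes with the highest number. From the compounds shown here alone, it also stays open whether a methyl or a longer chain on the amide-type nitrogen, or a carboxylic acid in place of carbamoyl, would keep this level.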